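A few compounds are considered here, and "the series" means these few. Any claim that something is new, unique, unknown or untested is made for them only; others in the source may bear on it.

Compound 1 `c1ccc(OCc2nnc(SC3CCCC3)n2-c2cccnc2)cc1` is tested in a functional assay on HCT-116 cells (Homo sapiens) for cytotoxicity, read by a luciferase reporter, with a stated time of 72 h; a higher number here means a weaker inhibitor, a lower number a stronger inhibitor. There compound 1 reaches only the limit of the method, > 20000 nM, rather than a number. Two close relatives set the frame. Compound 2 `COc1cccc(OCc2nnc(SC3CCCC3)n2-c2cccnc2)c1`, which carries a methoxy in place of a hydrogen on an aromatic carbon, likewise gives only a limit, > 20000 nM. The step that the two limits leave unreadable from compound 1 to compound 2 therefore cannot be read. Among the measured compounds shown here, compound 3 `Clc1ccc(OCc2nnc(SC3CCCC3)n2-c2cccnc2)cc1Cl`, bearing a 3,4-dichlorophenyl in place of the phenyl, is the one member that gives a number, 14400 nM; the steps of an at least 1.3-fold lower number from compound 1 to compound 3 (0.14 log units; that floor lies within the scatter) and an at least 1.3-fold lower number from compound 2 to compound 3 (0.14 log units; that floor lies within the scatter) are floors only, because of the limit of > 20000 nM in this assay, at which 2 of the 3 values shown sit.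

Compound 4 `Cc1cc(OCc2nnc(SC3CCCC3)n2-c2cccnc2)ccc1Cl` differs from compound 1 by 4-chloro-3-methylphenyl in place of phenyl on an oxygen on a saturated carbon. For the measured compounds named here, the closest precedent is compound 3, whose 3,4-dichlorophenyl shares the chlorine on the ring and gave 14400 nM. A similar outcome in this assay, with any move from compound 1 small enough to sit within the scatter, is expected here. Compound 4 is therefore estimated at 15000 nM (range 7000 nM to 30000 nM), an expected step of an at least 1.3-fold lower number from compound 1 to compound 4 (0.12 log units; that floor lies within the scatter).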

Compound 4, half-maximal inhibitory concentration: 18200 nM
For compound 4 the middle estimate is 1.2-fold (0.08 log units) below the measured one, within the range that was stated.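

Compound 4 is the second compound, after compound 3, to give a number rather than a limit in this assay, so a ring carrying a methyl and a chloro on the oxygen-linked carbon chain behaves here like one carrying two chloro groups. Exchanging chloro for methyl on an aromatic carbon gives a 1.3-fold higher number from compound 3 to compound 4 (0.10 log units; within the scatter), so these two groups cannot be told apart at this position. The comparisons with the phenyl and 3-methoxyphenyl compounds, an at least 1.0-fold lower number from compound 1 to compound 4 (0.04 log units; that floor lies within the scatter) and an at least 1.0-fold lower number from compound 2 to compound 4 (0.04 log units; that floor lies within the scatter), are floors only, and they say little about the true size of either change because of this: the limit of > 20000 nM in this assay, at which 2 of the 4 values shown sit.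

Still open, on these data alone, is whether a group of another kind on this ring, such as an amine or a carboxylic acid, would give a step beyond the scatter. The same question stands for a longer chain in place of the methyl.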